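Hydroxy in place of methoxy on a cytotoxic pyrazole series

This account rests on a few compounds, and the source may have more. Where it says the series, first, only, none or still open, it means among the compounds named here.

Measured so far:
- compound 1, `COc1cc(C)cc(-c2nn(CC#N)cc2-c2ccc(-c3cccc(C(C)=O)c3)nc2)c1`: 92%
- compound 2, `Cc1cc(O)cc(-c2nn(CC#N)cc2-c2ccnc(-c3ccc(Oc4ccccc4)cc3)c2)c1`: 91%
- compound 3, `COc1cc(C)cc(-c2nn(CC#N)cc2-c2ccnc(-c3ccc(N(C)C)cc3)c2)c1`: 22%

Of the compounds shown here, three sharing one core have been tested in a functional assay on 786-0 cells (Homo sapiens) for cytotoxicity, read by sulforhodamine B assay, with a stated time of 48 h, tested at 100 nM; a higher number here means a weaker effect of the compound at the concentration tested, a lower number a stronger effect. Compound 1 gives 92% and compound 2 gives 91%; these two values lie within the scatter of each other. Compound 3 stands apart: its value of 22% is the lowest of the three, and its gaps to compound 2 and to compound 1 both lie beyond the scatter, so compound 3 is the most active compound measured here.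

Compound 4, `Cc1cc(O)cc(-c2nn(CC#N)cc2-c2ccnc(-c3ccc(N(C)C)cc3)c2)c1`, has not yet been measured. It differs from compound 3 in one place:

hydrogen in place of methyl on an oxygen on an aromatic ring

Going by the values given here, no pair of measured compounds differs in this single place, so the size of this step has no direct precedent. Compound 2 also carries the hydroxy group, but it differs from compound 3 in a second place as well, so its value cannot be read as the effect of this change alone. In this assay a modest increase from compound 3 to compound 4 is expected, roughly at the edge of the scatter: a number 13 percentage points higher from compound 3 to compound 4 (beyond the scatter). Compound 4 is estimated to give 35%, with a likely range from 15% to 75%.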

Compound 4, a percentage reported as activity, at one concentration (the size of the read-out at that concentration, not a potency): 91%
For compound 4 the middle estimate is 56 percentage points below the measured one; measured number outside the range, above it.
By their numbers in this assay, from the lowest: compound 3; then compounds 2, 4 and 1 (each within the scatter of the next).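

The change from methoxy to hydroxy gives a number 69 percentage points higher from compound 3 to compound 4 (beyond the scatter) in this assay and so shows that this oxygen's methyl, a single carbon, matters greatly in the setting of compound 3: removing it leaves the hydrogen on the oxygen and takes away the clear effect seen at the tested concentration. Going by these compounds alone, with the hydroxy group fixed, changing phenoxy to dimethylamino gives no change at the digits printed from compound 2 to compound 4 (within the scatter) and so shows that dimethylamino alone does not bring that effect back; in this pair, it is seen only with the methoxy group present, as in compound 3. Nothing available here explains why removing this methyl has so large an effect.

The compounds shown leave open whether the effect needs methoxy exactly, or would survive with ethoxy, a longer chain on the same oxygen, or with an amine in place of that oxygen. They also leave open whether methoxy would have the same large influence when paired with a different group on the far aromatic ring, such as a carboxylic acid.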